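A few compounds are considered here, and "the series" means these few. Any claim that something is new, unique, unknown or untested is made for them only; others in the source may bear on it.

In an assay on T-REx-293 cells for inhibition of potassium channel subfamily T member 1 (Homo sapiens), read by patch clamp (a higher number here means a weaker inhibitor, a lower number a stronger inhibitor), compound 1 `Cc1cc(-c2noc([C@H](C)NC(=O)c3cc(C(F)(F)F)nn3C)n2)ccn1` gives 165 nM, compound 2 `C[C@H](NC(=O)c1cc(C(F)(F)F)nn1C)c1nc(-c2cccnc2)no1` gives 11800 nM, and compound 3 `Cc1cc(-c2noc([C@H](C)NC(=O)c3cc(C(F)(F)F)nn3C)n2)ncn1` gives 1410 nM, the second highest of the three numbers. The step from compound 3 to compound 4 `COc1cc(-c2noc([C@H](C)NC(=O)c3cc(C(F)(F)F)nn3C)n2)ccn1` is 2-methoxypyridin-4-yl in place of 6-methylpyrimidin-4-yl on an aromatic carbon. Among the measured compounds shown here, two measured steps bear on it: an 8.5-fold higher number from compound 1 to compound 3 (0.93 log units; beyond the scatter), and an 8.4-fold lower number from compound 2 to compound 3 (0.92 log units; beyond the scatter). Compound 4 carries 2-methoxypyridin-4-yl, a close kin of the 2-methylpyridin-4-yl of compound 1, whose number in this assay is 165 nM. The change is therefore expected to undo most of the earlier rise, a modest step lower in this assay, estimated as a 5.6-fold lower number from compound 3 to compound 4 (0.75 log units; beyond the scatter). For compound 4 the estimate in this assay is 250 nM, with a range from 80 nM to 800 nM.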

Compound 4, half-maximal inhibitory concentration: 27 nM
Compound 4: middle estimate off by 9.3-fold (0.97 log units), on the high side, and the stated range ends above it.
By their numbers in this assay, from the lowest: compound 4; then compound 1; then compound 3; then compound 2.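

In this assay methoxy in place of methyl on the pyridin-4-yl group gives a 6.1-fold lower number from compound 1 to compound 4 (0.79 log units; beyond the scatter) and shows that this one small substituent still moves the number beyond the scatter. The group also outdoes both other rings at this aromatic carbon, with a 52-fold lower number from compound 3 to compound 4 (1.72 log units; beyond the scatter) and with a 440-fold lower number from compound 2 to compound 4 (2.64 log units; beyond the scatter) as the widest gap in the set. No measurement given accounts for these differences. The compounds shown leave open whether ethoxy or an amine in place of methoxy would hold the number this low, and whether the gain carries over to other groups on the shared core.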